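The source may hold more compounds than are shown below. What is called first, only, known or untested is meant among the compounds shown, and "the series" means these compounds.

Compound 1 `CCCCC(O)CC(=O)O[C@H](CC=C(C)C)C1=CC(=O)c2c(O)ccc(O)c2C1=O` gives 72200 nM.
Compound 2 `CC(C)=CC[C@@H](OC(=O)C1CCCCO1)C1=CC(=O)c2c(O)ccc(O)c2C1=O` reaches only the assay limit, > 100000 nM.
Compound 3 `CC[C@](C)(O)CC(=O)O[C@H](CC=C(C)C)C1=CC(=O)c2c(O)ccc(O)c2C1=O` gives 30200 nM.

In a functional assay on HeLa cells (Homo sapiens) for cytotoxicity, read by MTT assay (on this read-out lower numbers stand for stronger inhibition and higher numbers for weaker inhibition), compound 1 holds the higher of the two plain numbers, the other being compound 3. Compound 4 `COCCO[C@H](CC=C(C)C)C1=CC(=O)c2c(O)ccc(O)c2C1=O` differs from compound 1 in one place: 2-methoxyethyl in place of (2-hydroxyhexyl)carbonyl on an oxygen on a saturated carbon. Two measured steps change the group on that same oxygen. There is an at least 1.3-fold higher number from compound 1 to compound 2 (0.14 log units; that floor lies within the scatter), a floor that is within scatter, and a 2.4-fold lower number from compound 1 to compound 3 (0.38 log units; beyond the scatter), a modest step; the limit of > 100000 nM in this assay, at which 1 of the 3 values shown sits, marks the limit in question. Neither step replaces a carbonyl-bearing group by a 2-methoxyethyl, so the guidance is weak, and the expected step is a 1.1-fold higher number from compound 1 to compound 4 (0.04 log units; within the scatter). Compound 4 is therefore estimated at 80000 nM, with an expected range of 30000 nM to 200000 nM.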

Compound 4, half-maximal inhibitory concentration: 62400 nM
Beside the measured number, compound 4's estimate is 1.3-fold (0.11 log units) above it, and the stated range covers the measured number.
By their numbers in this assay, from the lowest: compound 3; then compounds 4 and 1 (each within the scatter of the next). At a limit, above all of these: compound 2.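

In this assay the ester group on this oxygen can give way to 2-methoxyethyl, which has no hydrogen-bond donor, with only a 1.2-fold lower number from compound 1 to compound 4 (0.06 log units; within the scatter) as the result. The (2-hydroxy-2-methylbutyl)carbonyl group still stands apart from the ether, with a 2.1-fold higher number from compound 3 to compound 4 (0.32 log units; beyond the scatter) on that change. The comparison with the (oxan-2-yl)carbonyl ester gives an at least 1.6-fold lower number from compound 2 to compound 4 (0.20 log units; that floor lies within the scatter) and is only a floor, as compound 2 stands at a limit: the limit of > 100000 nM in this assay, at which 1 of the 4 values shown sits.

As far as these compounds go, whether an amine, a carboxylic acid or a longer ether chain on this oxygen would shift the number remains open. So does whether the hydroxyl or the methyl branch of compound 3 accounts for its separation from compound 4.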